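The source may report more compounds than this note shows. Statements on the series, on what has been measured and on what is new or still open speak of the compounds shown alone.

Compound 2 `O=C(CN1CCN(c2nnc(Cc3ccccc3)c3ccccc23)CC1)Nc1ccc(F)c(C(F)(F)F)c1` sits in the middle of three measured compounds in a functional assay on MDA-MB-231 cells (Homo sapiens) for cytotoxicity, read by MTT assay, with a stated time of 72 h (a higher number here means a weaker inhibitor, a lower number a stronger inhibitor), where compound 2 gives 760 nM. Compound 1 `Cc1ccc(NC(=O)CN2CCN(c3nnc(Cc4ccccc4)c4ccccc34)CC2)c(C)c1` gives 181000 nM in this assay, and compound 3 `O=C(CN1CCN(c2nnc(Cc3ccncc3)c3ccccc23)CC1)Nc1ccc(F)c(C(F)(F)F)c1` gives 1.9 nM. The two measured steps are both large: a 240-fold lower number from compound 1 to compound 2 (2.38 log units; beyond the scatter) and a 400-fold lower number from compound 2 to compound 3 (2.60 log units; beyond the scatter).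

Compound 4 `Cc1cccc(Cl)c1NC(=O)CN1CCN(c2nnc(Cc3ccccc3)c3ccccc23)CC1` has not yet been measured in this assay. It differs from compound 2 at the group on the amide-type nitrogen: 2-chloro-6-methylphenyl in place of 4-fluoro-3-(trifluoromethyl)phenyl on an amide-type nitrogen.

Among the measured compounds shown here, only one of the measured steps bears on this change, the step of a 240-fold lower number from compound 1 to compound 2 (2.38 log units; beyond the scatter), which swapped one aryl group for another at the same amide-type nitrogen. That step shows that the identity of this aryl group can move the number by a very large amount. The 2-chloro-6-methylphenyl of compound 4 resembles neither the 4-fluoro-3-(trifluoromethyl)phenyl of compound 2 nor the 2,4-dimethylphenyl of compound 1 closely, so the expectation is uncertain, but a number somewhere between the values of compound 1 and compound 2 seems most likely, a step upward from compound 2 of a 26-fold higher number from compound 2 to compound 4 (1.42 log units; beyond the scatter) being expected. Compound 4 is therefore estimated at 20000 nM, with a range from 2000 nM to 150000 nM.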

Compound 4, half-maximal inhibitory concentration: 3920 nM
The estimate for compound 4 lay 5.1-fold (0.71 log units) above the measured number; low and high end bracket the measured number.
By their numbers in this assay, from the lowest: compound 3; then compound 2; then compound 4; then compound 1.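

At the amide-type nitrogen of the shared core, the 2-chloro-6-methylphenyl group in place of 4-fluoro-3-(trifluoromethyl)phenyl in this assay gives only a 5.2-fold higher number from compound 2 to compound 4 (0.71 log units; beyond the scatter) and so stays much nearer to compound 2 than to compound 1, even though the entering group has no fluorine and fewer heavy atoms. The swap of 2-chloro-6-methylphenyl for 2,4-dimethylphenyl gives a 46-fold lower number from compound 1 to compound 4 (1.66 log units; beyond the scatter) even though both groups carry methyl, so a methyl group alone does not set the number among compounds 1, 2 and 4; the two groups bearing halogen lie closer together here, and none of these three compounds goes against that. No measurement shown here accounts for these gaps.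

Among the compounds shown here, no pair here separates the chlorine of compound 4 from its methyl group, and how an unsubstituted phenyl or a 4-methoxyphenyl would fare at this nitrogen remains open. Also open, as far as these compounds go, is whether a 400-fold lower number from compound 2 to compound 3 (2.60 log units; beyond the scatter), seen with pyridin-4-yl in place of phenyl, would carry over to the 2-chloro-6-methylphenyl amide of compound 4.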